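From fluoro to methoxy on the aryl ring

A few compounds are considered here, and "the series" means these few. Any claim that something is new, unique, unknown or untested is made for them only; others in the source may bear on it.

For the measured compounds named here, compound 3 `O=C(CCCCCCc1ccccc1)c1ncc(-c2ccc(F)cc2)o1` gives 62 nM in an assay (Rattus norvegicus) for inhibition of Fatty-acid amide hydrolase 1 (Homo sapiens) (on this read-out lower numbers stand for stronger inhibition and higher numbers for weaker inhibition), the second highest of the three numbers measured so far. Its nearest neighbour is compound 2 `O=C(CCCCCCc1ccccc1)c1ncc(-c2ccc([N+](=O)[O-])cc2)o1`, which gives 50 nM in this assay; the step of a 1.2-fold higher number from compound 2 to compound 3 (0.09 log units; within the scatter) lies within the scatter, so the two cannot be ordered. Furthest away is compound 1 `COc1ccccc1-c1cnc(C(=O)CCCCCCc2ccccc2)o1`, which gives 400 nM in this assay; the step of a 6.5-fold lower number from compound 1 to compound 3 (0.81 log units; beyond the scatter) is beyond the scatter, as is the parallel step an 8.0-fold lower number from compound 1 to compound 2 (0.90 log units; beyond the scatter).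

Compound 4 `COc1ccc(-c2cnc(C(=O)CCCCCCc3ccccc3)o2)cc1` differs from compound 3 in one place: methoxy in place of fluoro on an aromatic carbon. Going by the values given here, no measured pair carries exactly this change. What the measured steps show is that a 4-nitrophenyl and a 4-fluorophenyl give numbers within the scatter of each other, while a 2-methoxyphenyl gives a clearly higher number than either. The methoxy of compound 4 belongs to a 4-methoxyphenyl, not to the 2-methoxyphenyl of compound 1, so the weakening seen for compound 1 need not carry over. Compound 4 is therefore expected to land close to compound 3, with a step of a 1.6-fold higher number from compound 3 to compound 4 (0.21 log units; within the scatter) that may stay within the scatter or lean toward a higher number. The estimate for compound 4 in this assay is 100 nM, within a range from 35 nM to 300 nM.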

Compound 4, inhibition constant: 100 nM
Beside the measured number, compound 4's estimate shows no gap at the digits printed, within the range that was stated.
By their numbers in this assay, from the lowest: compounds 2, 3 and 4 (each within the scatter of the next); then compound 1.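

In this assay the change from 4-fluorophenyl to 4-methoxyphenyl gives a step, a 1.6-fold higher number from compound 3 to compound 4 (0.21 log units; within the scatter), that stays within the scatter, and so does the step with nitro as the starting group, a 2.0-fold higher number from compound 2 to compound 4 (0.30 log units; within the scatter), so fluoro, nitro and methoxy at this place on the ring cannot be ordered. The methoxy group itself therefore does not go with a clearly higher number at this place. For the compounds shown here, the step of a 4.0-fold lower number from compound 1 to compound 4 (0.60 log units; beyond the scatter) is beyond the scatter and is the first pair here to carry the same methoxy group on both sides, so the higher number of compound 1 goes with the 2-methoxyphenyl arrangement and not with the presence of a methoxy group as such. Nothing available here explains this difference.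

As far as these compounds go, it remains open whether an amine or a carboxylic acid at this place would stay within the scatter of compound 4. From the compounds shown here alone, it is also open whether the gap between the 2-methoxyphenyl and 4-methoxyphenyl compounds would hold with a longer chain on the carbonyl.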